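Sulfonamide substitution on the side chain: compound 4

The source may hold more compounds than are shown below. What is called first, only, known or untested is meant among the compounds shown, and "the series" means these compounds.

Measured compounds in a functional assay (aorta) for antagonist activity, with Oryctolagus cuniculus as the target; on this read-out lower numbers stand for stronger inhibition and higher numbers for weaker inhibition:
compound 1 `CCCCc1ccc(CNC(C)=O)c(=O)n1Cc1ccc(-c2ccccc2-c2nn[nH]n2)cc1`, 3 nM
compound 2 `CCCCc1ccc(C)c(=O)n1Cc1ccc(-c2ccccc2-c2nn[nH]n2)cc1`, 7 nM
compound 3 `CCCCc1ccc(CNS(=O)(=O)c2ccccc2)c(=O)n1Cc1ccc(-c2ccccc2-c2nn[nH]n2)cc1`, 7 nM

Compound 2 stands level with compound 3 at the digits shown, and the two together give the highest numbers of the three. Within the data shown here, the step from compound 2 to the only other compound is a 2.3-fold higher number from compound 1 to compound 2 (0.37 log units; beyond the scatter), so compound 1 is the nearest thing to a clear outlier in this small set.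

The unmeasured compound 4 `CCCCc1ccc(CN(C)S(=O)(=O)c2ccc(C)cc2)c(=O)n1Cc1ccc(-c2ccccc2-c2nn[nH]n2)cc1` differs from compound 2 by methyl((4-methylphenyl)sulfonyl)amino in place of hydrogen on a saturated chain carbon bound to an aromatic carbon.

The step that bears most directly on this is no change at the digits printed from compound 2 to compound 3 (within the scatter), where a sulfonyl-bearing amino group entered at the same saturated chain carbon. A second step, a 2.3-fold higher number from compound 1 to compound 3 (0.37 log units; beyond the scatter), shows that exchanging an acetyl for a phenylsulfonyl on the amine nitrogen moved the number only modestly. Nothing here separates the effect of the methyl on the nitrogen or the methyl on the ring from the parent sulfonamide.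

Taken together, the change in compound 4 is expected to give a 1.1-fold higher number from compound 2 to compound 4 (0.06 log units; within the scatter). Compound 4 is therefore estimated at 8 nM in this assay, with a range of 3 nM to 20 nM.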

Compound 4, half-maximal inhibitory concentration: 8 nM
Estimate against measurement, compound 4: no gap at the digits printed, and the stated range covers the measured number.
By their numbers in this assay, from the lowest: compound 1; then compounds 2, 3 and 4 (each within the scatter of the next).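

In this assay, methyl((4-methylphenyl)sulfonyl)amino on the saturated chain carbon bound to an aromatic carbon gives a 1.1-fold higher number from compound 2 to compound 4 (0.06 log units; within the scatter), so this carbon carries a group of 12 heavy atoms with 0 hydrogen-bond donors without a step beyond the scatter. Against the (phenylsulfonyl)amino group the result is a 1.1-fold higher number from compound 3 to compound 4 (0.06 log units; within the scatter), which shows that the hydrogen on the sulfonamide nitrogen is not required for a number at this level. The acetamido compound stays apart, with a 2.7-fold higher number from compound 1 to compound 4 (0.43 log units; beyond the scatter).

No measurement in hand explains any of these steps. From the compounds shown here alone, the separate contributions of the methyl on the nitrogen and the methyl on the ring remain open, as does the outcome with a carboxylic acid or a primary amine on this carbon.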